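The source may report more compounds than this note shows. Statements on the series, on what has been measured and on what is new or still open speak of the compounds shown alone.

Measured so far:
Compound 1 `CN1CCC(OC(=O)c2ccccc2Cc2ccccc2)CC1`: 1.28
Compound 2 `CN1CCC(OC(=O)c2ccc(Cl)c(Cl)c2)CC1`: 1.08
Compound 3 `Cc1cccc(C)c1C(=O)OC1CCN(C)CC1`: 1.27

In a functional assay on the whole organism with Mus musculus as the target (on this read-out higher numbers stand for higher potency (the scale is a negative logarithm) and lower numbers for lower potency), the three numbers lie close together. Compound 2 gives the lowest of the three, yet its gaps to compound 3 and to compound 1 both fall within the scatter, so none of these compounds can be called more or less potent than another. Compound 4 `CN1CCC(OC(=O)c2ccc(Cl)cc2)CC1` has not yet been measured. It differs from compound 2 in one place: hydrogen in place of chloro on an aromatic carbon. Among the compounds with values here, no step between measured compounds shows what such a change does, so the expectation rests only on how close the measured numbers sit. The step is expected to be a number 0.07 log units higher from compound 2 to compound 4 (within the scatter), no larger than the scatter in this assay. Compound 4 is therefore estimated at 1.15, with the true number expected between 0.75 and 1.55.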

Compound 4, logarithm of the reciprocal of the active concentration, log(1/C): 1.11
For compound 4 the middle estimate is 0.04 log units above the measured one, and the stated range covers the measured number.
By their numbers in this assay, from the lowest: compounds 2, 4, 3 and 1 (each within the scatter of the next).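

In this assay, hydrogen in place of chloro on this aromatic carbon, ortho to a chloro group and meta to a large group, gives a number 0.03 log units higher from compound 2 to compound 4 (within the scatter) and so shows no readable effect. Unlike the earlier compounds, this pair differs in one place, so the chloro group here can be judged directly: its loss leaves no difference that stands out from the scatter. Nothing at hand gives a reason for this result. Still open, going by these compounds, is whether the remaining chloro group matters, and whether another group on this carbon, such as an amine or a carboxylic acid, would shift the number beyond the scatter.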